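Swapping a Carboxy Group for a Cyclopropyl Amide

The compounds below may be only part of what the source reports. "The series", "measured", "known", "first", "only" and "open" are said of these compounds alone.

Three measured compounds set the scene. Compound 1 `Cc1nc(-c2ccc(C(F)(F)F)cc2)sc1CNc1ccc(C(=O)O)cc1` carries a carboxy group on an aromatic carbon; in a functional assay on CHO cells for agonist activity at Free fatty acid receptor 1 (Homo sapiens), read by a luciferase reporter (a higher number here means a larger maximal response, a lower number a smaller maximal response), compound 1 reaches 10%. Compound 2 `O=C(O)/C=C/c1ccc(NCc2cccc(Oc3ccccc3)c2)cc1` belongs to a different series and in this assay compound 2 gives 76%, while compound 3 `CC(C)NC(=O)CCc1ccc(NCc2cccc(Oc3ccccc3)c2)cc1` gives 66%. Compound 1 therefore stands lowest of the three, well beyond the scatter below both compound 3 and compound 2.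

The unmeasured compound 4 `Cc1nc(-c2ccc(C(F)(F)F)cc2)sc1CNc1ccc([C@H]2C[C@@H]2C(=O)N(C)C)cc1` keeps the core of compound 1 and changes one thing: 2-(dimethylcarbamoyl)cyclopropyl in place of carboxy on an aromatic carbon. In plain terms, the acid is gone and an amide on a small carbon ring takes its place.

Going by the values given here, only one measured step speaks to such a change. Within the other series, a number 10 percentage points lower from compound 2 to compound 3 (within the scatter) shows that exchanging an acid-bearing group for an amide-bearing group left the maximal response essentially where it was. That step was measured on a different core, so its transfer to compound 1 is uncertain, but it gives no sign of a large move in either direction.

Compound 4 is therefore expected to stay near the low response of compound 1, with the estimated step of a number 15 percentage points higher from compound 1 to compound 4 (beyond the scatter). The estimate for compound 4 in this assay is 25%, within a range of 5% to 60%.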

Compound 4, largest response reached (reported as percent of maximum), in percent of the reference or control that the assay uses: 49%
Estimate against measurement, compound 4: 24 percentage points below; low and high end bracket the measured number.
By their numbers in this assay, from the lowest: compound 1; then compound 4; then compounds 3 and 2 (each within the scatter of the next).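

On the core of compound 1, the carboxy group is not required for a sizeable response in this assay, since replacing it with 2-(dimethylcarbamoyl)cyclopropyl gives a number 39 percentage points higher from compound 1 to compound 4 (beyond the scatter). This is the first measured step showing that a change at this position, on an aromatic carbon para to a large group, can move the maximal response well beyond the scatter, whereas the amide in the other series gave a number 10 percentage points lower from compound 2 to compound 3 (within the scatter), although that was a different group swap on a different core. The position therefore accepts a much larger group that has a three-membered ring, two defined stereocentres and no hydrogen-bond donor, and the response rises with it.

No measurement shown here explains why the response rises. From the compounds shown here alone, the swap also changes several things at once, so it remains open whether the gain follows the loss of the acid, the dimethylcarbamoyl group, the cyclopropyl ring or its stereochemistry, and a carboxylic acid on the same cyclopropyl ring, a dimethylcarbamoyl group directly on the aromatic carbon or the opposite stereoisomer would help to separate these.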